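The compounds below may be only part of what the source reports. "The series", "measured", "known", "first", "only" and "open" are said of these compounds alone.

Working notes on the aziridinylquinone series, step from compound 1 to compound 3.

Of the compounds shown here, two carry numbers so far. Compound 1 `CC1=C(N2CC2)C(=O)C(CC(C)OC(N)=O)=C(N2CC2)C1=O` gives 5.86 in a functional assay on L1210 cells (Mus musculus), with a stated time of 1 days (on this read-out lower numbers stand for lower potency and higher numbers for higher potency (the scale is a negative logarithm)), the higher of the two values on hand. Compound 2 `CCC1=C(N2CC2)C(=O)C(C(COC(N)=O)OC)=C(N2CC2)C1=O` gives 5.62 in this assay, a number that sits within the usual scatter of the value of compound 1, so no order between the two can be claimed. Going by the values given here, no pair of measured compounds differs in one place only, so no measured step is available to lean on.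

Compound 3 `CCC(OC)C1=C(N2CC2)C(=O)C(C)=C(N2CC2)C1=O` has not yet been measured. Relative to compound 1 it differs as follows: a group of 5 heavy atoms (4 carbon, 1 oxygen; no ring) in place of a group of 7 heavy atoms (4 carbon, 1 nitrogen, 2 oxygen; no ring), on a double-bonded ring carbon. The side chain that leaves carries the hydrogen-bond donor of compound 1; the 1-methoxypropyl group that enters carries none.

With no measured step of this kind in the series, the expectation rests on the structural change alone: a modest loss in this assay is expected for compound 3, beyond the scatter but not large, an expected step of a number 0.36 log units lower from compound 1 to compound 3 (beyond the scatter). Compound 3 is thus estimated at 5.5 in this assay, with a range from 5 to 6.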

Compound 3, logarithm of the reciprocal of the active concentration, log(1/C): 5.26
For compound 3 the middle estimate is 0.24 log units above the measured one; the measured number falls inside the stated range.
By their numbers in this assay, from the lowest: compound 3; then compounds 2 and 1 (each within the scatter of the next).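

Going by these compounds alone, on a double-bonded ring carbon of the shared core, exchanging the side chain of 7 heavy atoms for 1-methoxypropyl gives the first single-place step in this assay, and it is a number 0.60 log units lower from compound 1 to compound 3 (beyond the scatter). The step is modest, yet it shows that the number at this place depends on the group carried there, which compounds 1 and 2 could not show, as they offered no single-place comparison. Nothing measured on hand explains this step, and the entering group differs from the leaving one in heavy-atom count, hydrogen-bond donor count and hydrogen-bond acceptor count at once.

A single exchange cannot separate these differences, so the compounds shown leave open which of them goes with the lower number. They also leave open how this read-out would respond at the same ring carbon to a simple hydroxyl group, an amine, a carboxylic acid or a longer chain, and whether the step would hold on a core carrying a group other than methyl on the ring.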